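Aryl cyanoguanidines on a shared chromanol core

The source may hold more compounds than are shown below. What is called first, only, known or untested is meant among the compounds shown, and "the series" means these compounds.

Three compounds carry the same chromanol core and differ at the group attached to its benzylic position. Compound 1 `CCC(C)(C)/N=C(\NC#N)N[C@@H]1c2cc(C#N)ccc2OC(C)(C)[C@H]1O` gives 29800 nM in a functional assay (aorta) with Rattus norvegicus as the target; on this read-out lower numbers stand for stronger inhibition and higher numbers for weaker inhibition. Compound 2 `COC(=O)c1cc2ccccc2n1[C@@H]1c2cc(C#N)ccc2OC(C)(C)[C@H]1O` gives 33100 nM in this assay. Compound 3 `CC1(C)Oc2ccc(C#N)cc2[C@@H](/N=C(\NC#N)Nc2cccc(C(F)(F)F)c2)[C@@H]1O` gives 1600 nM in this assay, the lowest of the three numbers; its distances to compound 1 and to compound 2 both lie beyond the usual scatter, so compound 3 is the strongest inhibitor measured here.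

Compound 4 `Cc1ccc(N/C(=N/[C@@H]2c3cc(C#N)ccc3OC(C)(C)[C@H]2O)NC#N)cc1C` is not yet measured. It differs from compound 3 in one place: 3,4-dimethylphenyl in place of 3-(trifluoromethyl)phenyl on an amine nitrogen. Within the data shown here, no measured pair in this set shows the effect of exchanging one aryl group for another on this amine nitrogen, so the direction of the step rests on no measured precedent. The account expects a modest weakening in this assay, an estimated step of a 2.2-fold higher number from compound 3 to compound 4 (0.34 log units; beyond the scatter), and it estimates for compound 4 a value of 3500 nM, within a range from 1000 nM to 12000 nM.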

Compound 4, half-maximal inhibitory concentration: 5100 nM
Beside the measured number, compound 4's estimate is 1.5-fold (0.16 log units) below it; measured number inside the range.
By their numbers in this assay, from the lowest: compound 3; then compound 4; then compounds 1 and 2 (each within the scatter of the next).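

Among these compounds, compounds 3 and 4 give the first measured exchange of one aryl group for another on this amine nitrogen: in this assay, 3,4-dimethylphenyl in place of 3-(trifluoromethyl)phenyl gives a 3.2-fold higher number from compound 3 to compound 4 (0.50 log units; beyond the scatter) and stays beyond the scatter. The aromatic ring of carbon stays in place in this pair, so the number at this position responds to the groups that ring carries, not only to the presence of an aryl group. Nothing measured here gives a reason for the size or direction of this step.

The compounds shown leave open how this position would respond to a phenyl ring carrying a methoxy group, a chlorine atom or a carboxylic acid, or to a pyridine ring in its place. They also leave open how 3-methylphenyl or 4-methylphenyl alone would compare with the 3,4-dimethylphenyl of compound 4.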